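Swapping fluoro for cyano on the fused ring of compound 3

The source may hold more compounds than are shown below. What is called first, only, known or untested is meant among the compounds shown, and "the series" means these compounds.

Of the compounds shown here, three built on a shared core have been measured in a functional assay on HEK293 cells for agonist activity at Free fatty acid receptor 1 (Homo sapiens), read by fluorescence and calcium flux, with a stated time of 10 min; on this read-out higher numbers stand for an effect only at larger amounts of compound and lower numbers for an effect already at smaller amounts. Compound 1 `O=C(O)CCc1ccc(OCC2COc3ccc(Cl)cc3O2)cc1F` gives 830 nM. Compound 2 `CC#CC(CC(=O)O)c1ccc(OCC2COc3ccc(Cl)cc3O2)cc1` gives 100 nM. Compound 3 `CC#C[C@@H](CC(=O)O)c1ccc(OC[C@H]2COc3ccc(F)cc3O2)cc1` gives 210 nM, which places compound 3 second highest of the three numbers: its value sits above that of compound 2 and below that of compound 1, and each of those gaps lies beyond the ordinary scatter of this assay.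

Compound 4 `CC#C[C@@H](CC(=O)O)c1ccc(OC[C@H]2COc3ccc(C#N)cc3O2)cc1` has not yet been measured. It differs from compound 3 in one place only: cyano in place of fluoro on an aromatic carbon. The substituent is exchanged on an aromatic carbon of the six-membered carbon ring within the fused two-ring system, with the rest of the molecule left as it is.

Going by the values given here, no pair of measured compounds here differs by this exchange alone, so there is no measured step to lean on. With only the value of compound 3 at 210 nM as an anchor, the expectation is a step from compound 3 to compound 4 of about a 1.1-fold lower number from compound 3 to compound 4 (0.02 log units; within the scatter), that is, no change beyond the scatter in either direction. Compound 4 is therefore estimated at 200 nM, within a range from 80 nM to 500 nM.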

Compound 4, half-maximal effective concentration: 2100 nM
Beside the measured number, compound 4's estimate is 11-fold (1.02 log units) below it, and the stated range ends below it.
By their numbers in this assay, from the lowest: compound 2; then compound 3; then compound 1; then compound 4.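

In this assay, going by these compounds alone, putting cyano in place of fluoro on this aromatic carbon gives a 10-fold higher number from compound 3 to compound 4 (1.00 log units; beyond the scatter), the first change in this set that can be read at a single place. The earlier compounds shown here could not show this, since compound 1 and compound 2 each differ from compound 3 in more than one place; the new step shows that the number depends strongly on which group sits at this position, and that moving from fluoro to cyano here means an effect appears only at larger amounts of compound. Nothing available explains why this exchange has such an effect, and the step alone cannot separate the extra heavy atom, the triple bond and the added hydrogen-bond acceptor that enter with cyano.

The compounds shown leave open whether the step is particular to cyano or would also appear with another group at this position, such as a methyl or a methoxy group. They also leave open whether the same exchange would have a step of similar size on the shorter acid chain of compound 1.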